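Shifting a Hydroxyl Group and the Expected Gain

The source may hold more compounds than are shown below. What is called first, only, known or untested is meant among the compounds shown, and "the series" means these compounds.

Three measured compounds share one core and differ in two places. Compound 1 `Oc1ccc(-c2cc(-c3ccc(F)cc3)cc(-c3ccccc3O)n2)cc1` carries a 2-hydroxyphenyl group and a fluoro group. In a functional assay on HCT-15 cells (Homo sapiens) for inhibition (a lower number here means a stronger inhibitor, a higher number a weaker inhibitor), compound 1 gives only a limit of the assay, > 50000 nM. Compound 2 `Oc1ccc(-c2cc(-c3ccc(F)cc3)cc(-c3cccc(O)c3)n2)cc1` carries a 3-hydroxyphenyl group instead, and in this assay compound 2 gives 5020 nM. For the measured compounds named here, the measured step of an at least 9.9-fold lower number from compound 1 to compound 2 (0.99 log units; beyond the scatter) is the one that resembles the change considered here. Compound 3 `Oc1ccc(-c2cc(-c3ccc(OC(F)(F)F)cc3)cc(-c3ccccc3O)n2)cc1` keeps the 2-hydroxyphenyl group and carries trifluoromethoxy in place of fluoro. In this assay compound 3 also gives only a limit, > 50000 nM. The step that the two limits leave unreadable from compound 1 to compound 3 cannot be sized because of the limit of > 50000 nM in this assay, at which 2 of the 3 values shown sit.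

Compound 4 `Oc1ccc(-c2cc(-c3ccc(OC(F)(F)F)cc3)cc(-c3cccc(O)c3)n2)cc1` has not yet been measured. It differs from compound 3 in one place: 3-hydroxyphenyl in place of 2-hydroxyphenyl on an aromatic carbon. Going by the values given here, the only measured step that bears on this change is an at least 9.9-fold lower number from compound 1 to compound 2 (0.99 log units; beyond the scatter), a gain whose full size is hidden by the limit. Among the compounds with values here, the same shift of the hydroxyl is therefore expected to lower the number in this assay to a similar degree, with the caution that only one such pair has been measured. The expected step is an at least 8.3-fold lower number from compound 3 to compound 4 (0.92 log units; beyond the scatter). Compound 4 is expected to give 6000 nM, with a range from 1500 nM to 30000 nM.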

Compound 4, half-maximal inhibitory concentration: 1380 nM
For compound 4 the middle estimate is 4.3-fold (0.64 log units) above the measured one; the measured number lies below the stated range.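

Moving the hydroxyl group, with a 3-hydroxyphenyl group in place of a 2-hydroxyphenyl group on the carbon next to the ring nitrogen, now proves beneficial in a second pair of compounds, with an at least 36-fold lower number from compound 3 to compound 4 (1.55 log units; beyond the scatter) in this assay. For the compounds shown here, with the 3-hydroxyphenyl group in place, the change from fluoro to trifluoromethoxy can be sized for the first time, and it gives a 3.6-fold lower number from compound 2 to compound 4 (0.56 log units; beyond the scatter). The same change cannot be read with the 2-hydroxyphenyl group, as compound 1 and compound 3 both give only a limit of the assay: the limit of > 50000 nM in this assay, at which 2 of the 4 values shown sit.

As far as these compounds go, it remains open whether moving the hydroxyl group helps more with trifluoromethoxy than with fluoro: the same change on two cores in this assay, an at least 9.9-fold lower number (0.99 log units; beyond the scatter) from compound 1 to compound 2 and an at least 36-fold lower number (1.55 log units; beyond the scatter) from compound 3 to compound 4; the limit leaves it open whether they differ Also open is how this assay would respond to an amine or a carboxylic acid in place of the hydroxyl group on the 3-hydroxyphenyl ring.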